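The source may hold more compounds than are shown below. What is called first, only, known or untested is meant among the compounds shown, and "the series" means these compounds.

In a functional assay on FM3A cells (Mus musculus) for antiproliferative activity, read by cell counting, with a stated time of 2 days (on this read-out lower numbers stand for stronger inhibition and higher numbers for weaker inhibition), compound 1 `COc1ccc(Nc2nc(N)c(C(=O)c3ccc(Cl)cc3)s2)cc1` gives 59 nM and compound 2 `COc1ccc(Nc2nc(N)c(C(=O)c3ccc(OC)c(OC)c3)s2)cc1` gives 71 nM, so these two values lie within the scatter of each other and compound 1 stands level with compound 2. Compound 3 `COc1ccc(Nc2nc(N)c(C(=O)c3ccc([N+](=O)[O-])cc3)s2)cc1` differs from compound 1 by nitro in place of chloro on an aromatic carbon, para to a large group (nitro in place of chloro on an aromatic carbon). Among the compounds with values here, no measured step shows this change, so only a small rise in the number in this assay is expected, perhaps none beyond the scatter. The estimated step is a 1.5-fold higher number from compound 1 to compound 3 (0.18 log units; within the scatter). For compound 3 the estimated value is 90 nM, with an expected range of 30 nM to 300 nM.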

Compound 3, half-maximal inhibitory concentration: 310 nM
Compound 3: the middle estimate sits 3.4-fold (0.54 log units) below what was measured; the measured number lies above the stated range.
By their numbers in this assay, from the lowest: compounds 1 and 2 (each within the scatter of the next); then compound 3.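

At this position, para to a large group, the change of nitro in place of chloro in this assay gives a 5.3-fold higher number from compound 1 to compound 3 (0.72 log units; beyond the scatter) and so carries a cost beyond the scatter. Within the data shown here, the earlier compounds offered no single-place step, so this is the first sign that the number depends on the group held here. The data offer no measurement that would account for the step.

As far as these compounds go, it remains open how an amine or a carboxylic acid would fare at this position. A single step also cannot show whether the rise is particular to nitro or extends to other replacements of chloro.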